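From methoxy to bromo: compound 2 to compound 4

The source may hold more compounds than are shown below. What is called first, only, known or untested is meant among the compounds shown, and "the series" means these compounds.

In a functional assay on A549 cells (Homo sapiens) for inhibition, read by MTT assay, with a stated time of 24 h (on this read-out lower numbers stand for stronger inhibition of growth and higher numbers for weaker inhibition of growth), compound 2 (`COc1ccc(C(=O)n2c(-c3cn(C)c4ccc(OC)cc34)nc3ccccc32)cc1`) gives 4900 nM, the lowest of three numbers, while compound 1 (`COc1ccc2c(c1)c(-c1nc3ccccc3n1C(=O)c1ccccc1OC)cn2C`) gives 11900 nM and compound 3 (`COc1ccc2c(c1)c(-c1nc3ccccc3n1C(=O)c1cccc(Br)c1)cn2C`) gives 24800 nM. Compound 4 (`COc1ccc(C(=O)n2c(-c3cn(C)c4ccc(Br)cc34)nc3ccccc32)cc1`) keeps the 4-methoxyphenyl of compound 2 on the carbonyl carbon but carries a different change: bromo in place of methoxy on an aromatic carbon. For the measured compounds named here, no measured step touches that place. The closest evidence is a 5.1-fold higher number from compound 2 to compound 3 (0.70 log units; beyond the scatter), where 3-bromophenyl replaces 4-methoxyphenyl on the carbonyl carbon, alongside a 2.4-fold lower number from compound 1 to compound 2 (0.39 log units; beyond the scatter) and a 2.1-fold higher number from compound 1 to compound 3 (0.32 log units; beyond the scatter). All three are modest, so only a modest rise is expected, on thin evidence. The expected step is a 1.8-fold higher number from compound 2 to compound 4 (0.26 log units; within the scatter). For compound 4 the estimate is 9000 nM, within a range of 3000 nM to 25000 nM.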

Compound 4, concentration for 50% growth inhibition: 11300 nM
Beside the measured number, compound 4's estimate is 1.3-fold (0.10 log units) below it, and the stated range covers the measured number.
By their numbers in this assay, from the lowest: compound 2; then compounds 4 and 1 (each within the scatter of the next); then compound 3.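

In this assay bromo in place of methoxy on this aromatic carbon of the shared core gives a 2.3-fold higher number from compound 2 to compound 4 (0.36 log units; beyond the scatter) and so shows that this position, not only the aryl group on the carbonyl carbon, moves the number. The step is modest, and methoxy holds the lower number of this pair. Nothing measured here accounts for the step. As far as these compounds go, whether an amine or a hydroxy group at this position would give a lower or a higher number stays open. So does whether the step would hold with 3-bromophenyl on the carbonyl carbon.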